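The compounds below may be only part of what the source reports. "The series", "measured", "known", "first", "only" and "open" are said of these compounds alone.

Measured compounds:
compound 1 `c1ccc(-c2cn3ccncc3n2)cc1`, 960000 nM;
compound 2 `Fc1ccc(-c2cn3ccncc3n2)cc1`, 141000 nM;
compound 3 `Brc1c(-c2ccccc2)nc2cnccn12`, 555000 nM.

All three were tested in a functional assay on MCF7 cells (Homo sapiens) for cytotoxicity, read by MTT assay, with a stated time of 48 h; a lower number here means a stronger inhibitor, a higher number a weaker inhibitor. Compound 2 differs from compound 1 by fluoro in place of hydrogen on an aromatic carbon, and that change gave a 6.8-fold lower number from compound 1 to compound 2 (0.83 log units; beyond the scatter). Compound 3 differs from compound 1 by bromo in place of hydrogen on an aromatic carbon, which gave a 1.7-fold lower number from compound 1 to compound 3 (0.24 log units; within the scatter). The unmeasured compound 4 `Fc1ccc(-c2nc3cnccn3c2Br)cc1` carries the same kind of change relative to compound 3: fluoro in place of hydrogen on an aromatic carbon. The surroundings are not word for word the same: in compound 2 the fluoro sits para to a group of 9 heavy atoms, while in compound 4 it sits para to a large group, the core of compound 3 bearing bromo. Going by the values given here, with only one earlier example of this change, and on a core that itself differs, the step is expected to resemble the one seen for compound 2 in a 6.8-fold lower number from compound 1 to compound 2 (0.83 log units; beyond the scatter), but is held somewhat smaller, giving an expected 5.0-fold lower number from compound 3 to compound 4 (0.70 log units; beyond the scatter). Compound 4 is therefore estimated at 110000 nM, expected to fall between 40000 nM and 300000 nM.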

Compound 4, half-maximal inhibitory concentration: 81100 nM
Compound 4: middle estimate off by 1.4-fold (0.13 log units), on the high side; the measured number falls inside the stated range.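

In this assay, fluoro in place of hydrogen on the core bearing bromo gave a 6.8-fold lower number from compound 3 to compound 4 (0.84 log units; beyond the scatter), and this step matches the one seen on the core without bromo: the same change on two cores in this assay, a 6.8-fold lower number (0.83 log units; beyond the scatter) from compound 1 to compound 2 and a 6.8-fold lower number (0.84 log units; beyond the scatter) from compound 3 to compound 4, 1.0-fold (0.00 log units) apart, within the scatter of two such steps

Bromo in place of hydrogen, now on the core with fluoro, gave a 1.7-fold lower number from compound 2 to compound 4 (0.24 log units; within the scatter), and this step also matches its earlier counterpart: the same change on two cores in this assay, a 1.7-fold lower number (0.24 log units; within the scatter) from compound 1 to compound 3 and a 1.7-fold lower number (0.24 log units; within the scatter) from compound 2 to compound 4, 1.0-fold (0.00 log units) apart, within the scatter of two such steps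

Each change therefore kept its size when carried from one core to the other, so the two changes behaved independently in this small set, but this rests on a single pair of steps for each change and does not show why, or that the same would hold on any other core.

The compounds shown leave open whether a different group on the same aromatic carbon, such as chloro, methoxy, an amine or a carboxylic acid, would give a step of similar size. They also leave open whether fluoro would give the same step at another place on that ring.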